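This account rests on a few compounds, and the source may have more. Where it says the series, first, only, none or still open, it means among the compounds named here.

The series is built around a shared anilide carbamate core that carries a selenium substituent on the aromatic ring. Compound 1 `CC(C)COC(=O)Nc1ccc([Se][Se]c2ccc(NC(=O)OCC(C)C)cc2)cc1` is a diselenide with isobutyl carbamates at both ends, compound 3 `O=C(Nc1ccc([Se][Se]c2ccc(NC(=O)OCc3ccccc3)cc2)cc1)OCc1ccccc1` is the matching diselenide with benzyl carbamates, and compound 2 `CCCOC(=O)Nc1ccc([Se]C#N)cc1` is a single-ring selenocyanate with a propyl carbamate. In a functional assay on PC-3 cells (Homo sapiens) for cytotoxicity, read by MTT assay, with a stated time of 72 h (on this read-out higher numbers stand for weaker inhibition of growth and lower numbers for stronger inhibition of growth), compound 1 gives 24200 nM, compound 3 gives 100 nM, and compound 2 gives 21100 nM. Among these three numbers compound 2 stands second highest; its value and that of compound 1 lie within the scatter of each other, so no order between them can be read, whereas the value of compound 3 lies far lower, well beyond the scatter.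

Compound 4 `CCCCOC(=O)Nc1ccc([Se]C#N)cc1` has not yet been measured in this assay. It differs from compound 2 by methyl in place of hydrogen on a saturated chain carbon, three bonds along the chain from an oxygen next to a carbonyl group. Among the compounds with values here, no pair of measured compounds differs in only this way, so the size of this step has no precedent here. Because compound 2 gives 21100 nM and the change is a single chain carbon, the step from compound 2 to compound 4 is expected to be small, a 1.2-fold lower number from compound 2 to compound 4 (0.09 log units; within the scatter), and not beyond the scatter. Compound 4 is therefore estimated at 17000 nM, within a range from 7000 nM to 40000 nM.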

Compound 4, concentration for 50% growth inhibition: 12400 nM
Compound 4: middle estimate off by 1.4-fold (0.14 log units), on the high side, and the stated range covers the measured number.
By their numbers in this assay, from the lowest: compound 3; then compounds 4, 2 and 1 (each within the scatter of the next).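

In this assay, within the data shown here, the step from propyl to butyl gives the first reading for this position, as the earlier compounds offered no pair differing in only one place. Adding methyl at the end of the chain of the selenocyanate gives a 1.7-fold lower number from compound 2 to compound 4 (0.23 log units; within the scatter), a step that stays within the scatter, so on this pair the position tolerates one further chain carbon without a change that can be read. This single pair gives no trend along the chain, and nothing in the data bears on why the step has this size.

The compounds shown leave open what a longer chain such as hexyl, or an amine or a carboxylic acid at the end of the chain, would do at this place in this assay. Among these compounds, they also leave open whether the same methyl in place of hydrogen would give a step of similar size on a diselenide, as no pair of diselenides here differs in this way.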